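Compound 1 and the effect of defined stereocentres

The source may report more compounds than this note shows. Statements on the series, on what has been measured and on what is new or still open speak of the compounds shown alone.

In a functional assay for inhibition, with Homo sapiens as the target (on this read-out higher numbers stand for weaker inhibition and lower numbers for stronger inhibition), compound 1 (`CC1(c2ccc(C(=N)N)cc2)NC(=O)N(CC(=O)NC(CC(=O)O)c2ccccc2)C1=O`) gives 200 nM. Compound 2 (`CC1(c2ccc(C(=N)N)cc2)NC(=O)N(CC(=O)NC(CC(=O)O)c2cccnc2)C1=O`) gives 100 nM, which is a 2.0-fold lower number from compound 1 to compound 2 (0.30 log units; within the scatter). Compound 3 (`CC(CC(=O)O)NC(=O)CN1C(=O)NC(C)(c2ccc(C(=N)N)cc2)C1=O`) gives 2000 nM, which is a 10-fold higher number from compound 1 to compound 3 (1.00 log units; beyond the scatter) and a 20-fold higher number from compound 2 to compound 3 (1.30 log units; beyond the scatter). Compound 1 therefore sits with compound 2, and compound 3 stands clear above both.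

Compound 4 (`C[C@@]1(c2ccc(C(=N)N)cc2)NC(=O)N(CC(=O)N[C@@H](CC(=O)O)c2ccccc2)C1=O`) differs from compound 1 as follows: the two compounds have the same atoms and bonds; at least one stereo element is drawn with a configuration in one of them and without one in the other: 2 of 3 stereo elements differ; a stereocentre at a saturated ring carbon is drawn without a configuration in compound 1 and S in compound 4; a stereocentre at a saturated chain carbon is drawn without a configuration in compound 1 and S in compound 4.

Going by the values given here, no measured step tests a configuration. The steps at the saturated chain carbon bear on this change only indirectly, showing that replacing the group there can move the number by as much as a 20-fold higher number from compound 2 to compound 3 (1.30 log units; beyond the scatter). The data do not say whether compound 1 is a mixture of stereoisomers. If it is, and the drawn S,S form carries the inhibition, a modest move towards a lower number is expected, although a move within the scatter remains possible.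

The expected step is a 2.9-fold lower number from compound 1 to compound 4 (0.46 log units; beyond the scatter). Compound 4 is estimated at 70 nM, with an expected range of 20 nM to 200 nM.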

Compound 4, half-maximal inhibitory concentration: 20 nM
For compound 4 the middle estimate is 3.5-fold (0.54 log units) above the measured one; low and high end bracket the measured number.
By their numbers in this assay, from the lowest: compound 4; then compounds 2 and 1 (each within the scatter of the next); then compound 3.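

Working notes: in this assay, drawing both stereocentres as S gives a 10-fold lower number from compound 1 to compound 4 (1.00 log units; beyond the scatter). With no atom or bond changed, the number moves as far as it does on replacing the phenyl group with methyl, where the step runs the other way: a 10-fold higher number from compound 1 to compound 3 (1.00 log units; beyond the scatter). Configuration therefore counts in this series alongside the group on the saturated chain carbon, and the step can be tied to it only through how the two compounds are drawn: the fact that one of compounds 1 and 4 is drawn with a defined configuration and the other without, at the place where they differ

The compounds shown do not separate the saturated ring carbon from the saturated chain carbon, nor do they say whether compound 1 is a mixture of stereoisomers. Also open, from the compounds shown here alone, is whether the S,S form holds its number with a pyridin-3-yl group in place of phenyl, or with a methyl ester in place of the carboxylic acid.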